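A few compounds are considered here, and "the series" means these few. Any claim that something is new, unique, unknown or untested is made for them only; others in the source may bear on it.

Measured compounds:

compound 1, `COc1ccc(-n2nc(Sc3ccc(Cl)cc3)cc(CC[C@@H](C)NC(=O)[C@H]3CNCC[C@@H]3c3cccc(Cl)c3)c2=O)cc1`, in a functional assay with Melanocortin receptor 4 (Homo sapiens) as the target, read by cAMP accumulation (on this read-out higher numbers stand for an effect only at larger amounts of compound and lower numbers for an effect already at smaller amounts), compound 1 gives 680 nM
compound 2, `COc1ccc(-n2nc(Sc3ccc(Cl)cc3)cc(CC[C@@H](C)NC(=O)[C@H]3CNCC[C@@H]3c3ccc(C)cc3)c2=O)cc1`, compound 2 gives 1100 nM
compound 3, `COc1ccc(-n2nc(Sc3ccc(Cl)cc3)cc(CC[C@@H](C)NC(=O)[C@H]3CCNC[C@@H]3c3ccc(Cl)cc3)c2=O)cc1`, compound 3 gives 150 nM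

Compound 3 has the lowest number of the three, and its gaps to compound 1 and to compound 2 both lie beyond the usual scatter, so compound 3 is the most potent compound measured here. Compound 4, `COc1ccc(-n2nc(Sc3ccc(Cl)cc3)cc(CC[C@@H](C)NC(=O)[C@H]3CCNC[C@@H]3c3ccc(F)cc3)c2=O)cc1`, has not yet been measured. It differs from compound 3 in one place: fluoro in place of chloro on an aromatic carbon.

Among the compounds with values here, only one measured step is available for comparison, a 1.6-fold higher number from compound 1 to compound 2 (0.21 log units; within the scatter). That step also changed the aromatic ring attached to the saturated ring, but it swapped both the kind and the place of the substituent, and it moved the number only within the scatter. Within the data shown here, no measured pair shows a chloro to fluoro exchange on that ring, so the step to compound 4 is judged without a direct precedent. Such an exchange is a small one by atom count, and the expectation is a modest shift, a 2.0-fold higher number from compound 3 to compound 4 (0.30 log units; within the scatter), towards a somewhat higher number in this assay. Compound 4 is therefore expected to give about 300 nM, within the range 120 nM to 750 nM.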

Compound 4, half-maximal effective concentration: 110 nM
For compound 4 the middle estimate is 2.7-fold (0.44 log units) above the measured one; measured number below the stated range.
By their numbers in this assay, from the lowest: compounds 4 and 3 (each within the scatter of the next); then compounds 1 and 2 (each within the scatter of the next).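

In this assay, replacing 4-chlorophenyl with 4-fluorophenyl gives a 1.4-fold lower number from compound 3 to compound 4 (0.13 log units; within the scatter) and thus leaves the two compounds indistinguishable on this read-out. Within the data shown here, this is the first measured pair in which only the halogen on this aromatic ring changes, with the rest of the molecule held constant, and in this pair fluoro at the place para to a large group serves as well as chloro, so chlorine itself is not required there to keep the number in this range. No measurement of any property is available to account for the close match between these two halogens.

These two compounds carry only halogens at this place, so they cannot show how far the tolerance extends: an unsubstituted phenyl ring, a nitrile, a methoxy group or an amine at the same place could behave quite differently. As far as these compounds go, it also remains open whether the same exchange would have so little consequence on a different ring position or with the other arrangement of the saturated ring seen in compound 1.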